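The compounds below may be only part of what the source reports. "The series", "measured", "known", "first", "only" and "open" are said of these compounds alone.

Of the compounds shown here, three built on one shared core have been measured in a functional assay on MDA-MB-435 cells (Homo sapiens) for cytotoxicity, read by MTT assay, with a stated time of 72 h; a lower number here means a stronger inhibitor, a higher number a weaker inhibitor. Compound 1 `N[C@H]1CC[C@H](Nc2c(C(=O)NCc3ccco3)nc(Br)c3cccnc23)CC1` stands at the edge of what the assay reports: in this assay compound 1 gives > 10000 nM, which is a limit and not a number, as the limit of > 10000 nM in this assay, at which 1 of the 3 values shown sits, records. Compound 2 `NCCNc1c(C(=O)NCc2ccc(F)cc2)nc(Br)c2cccnc12` gives 12000 nM in this assay, and compound 3 `CNCCCNc1c(C(=O)NCc2ccc(F)cc2)nc(Br)c2cccnc12` gives 11000 nM. Among the measured compounds shown here, the single step measured between neighbours, a 1.1-fold lower number from compound 2 to compound 3 (0.04 log units; within the scatter), concerns a saturated chain carbon two bonds along the chain from a nitrogen on an aromatic ring and lies within the scatter.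

Compound 4 `C[C@H](NC(=O)c1nc(Br)c2cccnc2c1N[C@H]1CC[C@H](N)CC1)c1ccc(F)cc1` keeps the rest of compound 1 and alters the amide end: 1-(4-fluorophenyl)ethyl in place of (furan-2-yl)methyl on an amide-type nitrogen. For the measured compounds named here, no measured pair changes the group on the amide-type nitrogen, so the step from compound 2 to compound 3 does not bear on this change, and the values of compound 2 and compound 3 show only that other members also give high numbers in this assay. With compound 1 at a limit and nothing pointing away from it, no shift beyond the scatter is expected in either direction. Compound 4 is therefore estimated at 12000 nM, within 5000 nM to 30000 nM, and may well return only a limit again. The step this estimate means, a step that the limit leaves unreadable from compound 1 to compound 4, is expected to remain within the scatter.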

Compound 4, half-maximal inhibitory concentration: > 10000 nM
Compound 4: no number, only a limit; the forecaster's own chance of this, stated with the estimate: 60%; the middle value does not contradict the limit.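

In this assay compound 4 gives > 10000 nM as a limit and not a number. With compound 1 also at a limit, no step can be read between compound 1 and compound 4. The compounds shown leave open whether 1-(4-fluorophenyl)ethyl and (furan-2-yl)methyl on the amide-type nitrogen differ at all in this assay on this core.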